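This account rests on a few compounds, and the source may have more. Where it says the series, first, only, none or still open, it means among the compounds named here.

Working notes on the selenium-bearing naphthoquinone series, tested in a functional assay on A498 cells (Homo sapiens) for cytotoxicity, read by MTT assay, with a stated time of 24 h; a lower number here means a stronger inhibitor, a higher number a weaker inhibitor.

Compound 1 `CC1=C([Se]CC(OC(=O)[C@@H](CO)NC(=O)OC(C)(C)C)C(=O)NC(C)(C)C)C(=O)c2ccccc2C1=O` carries a tert-butyl amide and a serine-derived ester bearing a free hydroxy group. In this assay compound 1 gives 5000 nM. Compound 2 `CC1=C([Se]CC(OC(=O)[C@@H](CO)NC(=O)OC(C)(C)C)C(=O)NCCCCCC(=O)OCc2ccccc2)C(=O)c2ccccc2C1=O`, in which the amide nitrogen carries the longer chain ending in a benzyl ester, gives 5000 nM in this assay. The two values stand level at the digits shown, so compound 1 sits with its nearest neighbour, compound 2, with no change beyond the usual scatter. Going by the values given here, no other pair of measured compounds differs in a single place, so no directional step between measured compounds is available to lean on.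

Compound 3 `CC1=C([Se]CC(OC(=O)[C@@H](CSSC(C)(C)C)NC(=O)OC(C)(C)C)C(=O)NC(C)(C)C)C(=O)c2ccccc2C1=O` is not yet measured. Relative to compound 1 the change is ((tert-butyl)sulfanyl)sulfanyl in place of hydroxy on a saturated chain carbon, two bonds along the chain from an amide-type nitrogen and a carbonyl carbon. With the measured pair showing no movement between a small and a much larger amide substituent, the expectation is that the step of no change at the digits printed from compound 1 to compound 3 (within the scatter) lies within the scatter rather than beyond it, in either direction. The estimate for compound 3 in this assay is therefore 5000 nM, with a range from 2000 nM to 12000 nM.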

Compound 3, half-maximal inhibitory concentration: 5000 nM
The estimate for compound 3 equals the measured number at the digits printed; the measured number falls inside the stated range.
By their numbers in this assay, from the lowest: compounds 1, 2 and 3 (each within the scatter of the next).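

In this assay, going by these compounds alone, the earlier compounds spoke only to the amide substituent, and this result gives the first reading at the serine-derived side chain. Here ((tert-butyl)sulfanyl)sulfanyl in place of hydroxy, on a saturated chain carbon, two bonds along the chain from an amide-type nitrogen and a carbonyl carbon, gives no change at the digits printed from compound 1 to compound 3 (within the scatter) and so leaves the read-out where it stood. The free hydroxy is therefore not required at this position for the level seen in this series, since the swap from 1 heavy atom to 6 heavy atoms, and from 1 hydrogen-bond donor to 0, carries no visible cost or gain.

Still open, on these data alone, is whether an amine or a carboxylic acid on the same chain carbon, or a longer chain in place of the tert-butyl on the outer sulfur, would move the value at all. Also open is whether the same change holds with the benzyl ester chain on the amide nitrogen, and nothing shown bears on why the value stays put.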